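This account rests on a few compounds, and the source may have more. Where it says the series, first, only, none or still open, it means among the compounds named here.

Of the compounds shown here, two of a shared core have been measured in a functional assay on MCF7 cells (Homo sapiens) for antiproliferative activity, read by sulforhodamine B assay, with a stated time of 48 h; a higher number here means a weaker inhibitor, a lower number a stronger inhibitor. Compound 1 `CCCC(=O)Nc1ccc(S(=O)(=O)Oc2ccccc2C(C)C)cc1` gives 6600 nM, and compound 2 `CCCC(=O)Nc1ccc(S(=O)(=O)Oc2ccccc2I)cc1` gives 9700 nM. Going by the values given here, compound 2 therefore has the higher of the two numbers, yet the only step between them, a 1.5-fold higher number from compound 1 to compound 2 (0.17 log units; within the scatter), is within the scatter, so the two cannot be ordered.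

Compound 3 `CC(C)C(=O)Nc1ccc(S(=O)(=O)Oc2ccccc2I)cc1` differs from compound 2 by isopropyl in place of propyl on a carbonyl carbon. Among the compounds with values here, no measured step touches the acyl chain: the single step on hand, a 1.5-fold higher number from compound 1 to compound 2 (0.17 log units; within the scatter), concerns the aromatic carbon on the other ring and says nothing about branching at the carbonyl. The change is a rearrangement of the same atoms, without ring, donor or acceptor, and nothing in the data points in either direction.

The expectation for compound 3 is therefore a step of no change at the digits printed from compound 2 to compound 3 (within the scatter), none beyond the scatter, with an estimated value of 9700 nM and a range from 4000 nM to 24000 nM.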

Compound 3, half-maximal inhibitory concentration: 8100 nM
Estimate against measurement, compound 3: 1.2-fold (0.08 log units) above; the measured number falls inside the stated range.
By their numbers in this assay, from the lowest: compounds 1, 3 and 2 (each within the scatter of the next).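

In this assay the swap of propyl for isopropyl on the carbonyl carbon gives a 1.2-fold lower number from compound 2 to compound 3 (0.08 log units; within the scatter) and so the acyl chain has its first measured step. Branching this chain, with the same atoms joined differently, gives a number that cannot be told apart from that of the unbranched chain, so this place on the shared core joins the aromatic carbon of the other ring as a second site where the one change read so far stays within the scatter. No evidence at hand bears on this result.

On these data alone, whether a longer chain on the carbonyl carbon, or a chain carrying an amine or a carboxylic acid there, would give a step beyond the scatter stays open. As far as these compounds go, it is also open whether a methoxy group or a nitrile in place of the iodo group would do so.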